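The compounds below may be only part of what the source reports. "The series", "measured", "known", "first", "only" and "open" are said of these compounds alone.

Of the compounds shown here, three that share one core have been measured in an ADME assay on Vero cells (Chlorocebus sabaeus) for cytotoxicity, read by resazurin assay, with a stated time of 72 h; a lower number here means a stronger inhibitor, a higher number a weaker inhibitor. Compound 1 (`Cc1ccc(C(=O)CCN2CCN(c3ccc(F)cc3)CC2)cc1`) gives 55400 nM, compound 2 (`Cc1ccc(C(=O)CCN2CCN(c3ccc(C(F)(F)F)cc3)CC2)cc1`) gives 140000 nM, and compound 3 (`O=C(CCN1CCN(c2ccc(C(F)(F)F)cc2)CC1)c1ccc(F)c(Cl)c1`) gives 74500 nM. Compound 2 stands clearly apart only from compound 1, with a 2.5-fold higher number from compound 1 to compound 2 (0.40 log units; beyond the scatter). Compound 4 (`O=C(CCN1CCN(c2ccc(C(F)(F)F)cc2)CC1)c1ccc(OC(F)(F)F)cc1`) has not yet been measured. It differs from compound 2 by having trifluoromethoxy in place of methyl on an aromatic carbon. The most relevant measured change also replaces the methyl-bearing aromatic group of compound 2, and it is a 1.9-fold lower number from compound 2 to compound 3 (0.27 log units; within the scatter). The step from compound 1 to compound 2 changes a different aromatic group, so it offers little guidance here. Among the measured compounds shown here, no measured compound carries trifluoromethoxy, so the expectation remains loose: a slightly lower number, with no step beyond the scatter. The expected change is a 1.4-fold lower number from compound 2 to compound 4 (0.15 log units; within the scatter). The estimated value for compound 4 is 100000 nM, with an expected range of 45000 nM to 200000 nM.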

Compound 4, half-maximal inhibitory concentration: 64900 nM
Beside the measured number, compound 4's estimate is 1.5-fold (0.19 log units) above it; the measured number falls inside the stated range.
By their numbers in this assay, from the lowest: compounds 1, 4, 3 and 2 (each within the scatter of the next, the first and the last beyond it).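

In this assay, putting trifluoromethoxy in place of methyl on the six-membered aromatic ring gives a 2.2-fold lower number from compound 2 to compound 4 (0.33 log units; beyond the scatter) and so shows a modest but readable effect at this position. The earlier change to this part of compound 2 replaced the whole 4-methylphenyl group with 3-chloro-4-fluorophenyl, and a 1.9-fold lower number from compound 2 to compound 3 (0.27 log units; within the scatter) did not clear the usual scatter. Nothing available here explains why the number moves with this change.

The compounds shown leave open whether the step comes from the added oxygen or from the fluorines, and a plain methoxy or a single fluoro at the same position would separate the two. They also leave open whether trifluoromethoxy gives a similar step when the other aromatic ring carries fluoro, as in compound 1, rather than trifluoromethyl.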